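Mirror-image carboxylic acid on the piperidine ring

The source may hold more compounds than are shown below. What is called first, only, known or untested is meant among the compounds shown, and "the series" means these compounds.

The measured compounds:
compound 1, `COc1ccc(/C=C\c2cc(OC)c(OC)c(OC)c2)cc1OCc1ccc(CN2CCCC[C@H]2C(=O)O)cc1` — > 10000 nM
compound 2, `COc1ccc(/C=C\c2cc(OC)c(OC)c(OC)c2)cc1OCc1ccc(CN2CCCCC2C(=O)NCCN)cc1` — 4600 nM
compound 3, `COc1ccc(/C=C\c2cc(OC)c(OC)c(OC)c2)cc1OCc1ccc(CNCCN(C)C)cc1` — > 10000 nM

In a functional assay on B16-F10 cells (Mus musculus) for antiproliferative activity, read by CCK-8 assay, with a stated time of 48 h (a higher number here means a weaker inhibitor, a lower number a stronger inhibitor), compound 1 reaches only the upper limit of the assay, > 10000 nM. Compound 2 gives a real number, 4600 nM. Compound 3 again sits at the limit, > 10000 nM. Between them the steps are an at least 2.1-fold lower number from compound 1 to compound 2 (0.33 log units; beyond the scatter) and an at least 2.1-fold higher number from compound 2 to compound 3 (0.33 log units; beyond the scatter), while a step that the two limits leave unreadable from compound 1 to compound 3; this follows from the limit of > 10000 nM in this assay, at which 2 of the 3 values shown sit.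

Compound 4, `COc1ccc(/C=C\c2cc(OC)c(OC)c(OC)c2)cc1OCc1ccc(CN2CCCC[C@@H]2C(=O)O)cc1`, is the mirror partner of compound 1 at one centre: the two compounds have the same atoms and bonds and differ only in configuration as drawn: 1 of 2 stereo elements differ; a stereocentre at a saturated ring carbon is drawn S in compound 1 and R in compound 4. Within the data shown here, none of the measured steps bears on this change, since each of them swaps the whole group on the saturated chain carbon rather than turning a single stereocentre. Among the measured compounds shown here, with no comparable step to lean on, and with compound 1 already at the limit, the expectation is that compound 4 stays near that limit, so the step that the limit leaves unreadable from compound 1 to compound 4 is expected to lie within the scatter. Compound 4 is therefore estimated at 12000 nM, between 5000 nM and 30000 nM, most likely reported as a limit.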

Compound 4, half-maximal inhibitory concentration: > 10000 nM
Compound 4 was reported as a limit; the forecaster's own chance of this, stated with the estimate: 75%; the middle value is on the limit's open side.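

In this assay compound 4 gives > 10000 nM, which is a limit of the assay and not a number. Putting 2-carboxypiperidin-1-yl in place of 2-((2-aminoethyl)carbamoyl)piperidin-1-yl gives an at least 2.1-fold higher number from compound 2 to compound 4 (0.33 log units; beyond the scatter), so the drop in activity seen with the S acid also appears with the R acid. The steps to compound 4 from compound 1 and from compound 3 cannot be read, so any difference between the two mirror-image acids stays hidden, even though this pair isolates a single stereocentre: the limit of > 10000 nM in this assay, at which 3 of the 4 values shown sit.

Going by these compounds, whether turning the same stereocentre would change the value of the amide, where a real number can be read, remains open. So does what a methyl ester or a hydroxamic acid would give in place of the carboxylic acid.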